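A few compounds are considered here, and "the series" means these few. Any claim that something is new, unique, unknown or untested is made for them only; others in the source may bear on it.

Measured in an ADME assay for pharmacokinetics, read by HPLC, in phosphate buffer, with a stated time of 72 h, at pH 7.4, tested at 250 uM; on this read-out higher numbers stand for a longer-lived compound and lower numbers for a shorter-lived compound:
Compound 1 `C=CC(=O)Oc1cc(C(F)(F)F)cc(C(F)(F)F)c1` — < 0.017 h, a limit of the assay.
Compound 2 `O=C1C=CC(=O)N1c1cc(C(F)(F)F)cc(C(F)(F)F)c1` — < 0.017 h, a limit of the assay.

Compound 2 stands at the limit of < 0.017 h in this assay, at which 2 of the 2 values shown sit, so its place among the numbers is known only as a limit, and the step that the two limits leave unreadable from compound 1 to compound 2 cannot be given a size. Compound 3 `C=Cc1cc(C(F)(F)F)cc(C(F)(F)F)c1` differs from compound 2 by a group of 2 heavy atoms (2 carbon; no ring) in place of a group of 7 heavy atoms (4 carbon, 1 nitrogen, 2 oxygen; one five-membered non-aromatic ring with 1 hetero atom), on an aromatic carbon. Among the compounds with values here, no measured step bears on this change with a readable size; the only step shown sits between two limits. The expectation for compound 3 therefore rests on the structural change alone: the group that leaves carries nitrogen and oxygen, while what enters is a vinyl group, carbon only and without a ring. On that basis a step of an at least 4200-fold higher number from compound 2 to compound 3 (3.62 log units; beyond the scatter) is expected in this assay, in the direction of a longer-lived compound. Compound 3 is estimated at 72 h, within a range from 10 h to 500 h, and it is quite possible that the assay will again report only a limit, this time at its upper end.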

Compound 3, half-life: > 50 h
Compound 3: only a limit was reported; the forecaster's own chance of this, stated with the estimate: 60%; the middle value does not contradict the limit.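

Within the data shown here, until now, the two compounds with an oxygen-bearing group on this aromatic carbon sat together at the bottom of this assay, and the step between them cannot be read; vinyl at the same place, meta to two trifluoromethyl groups, gives the first steps of readable size, an at least 2900-fold higher number from compound 2 to compound 3 (3.46 log units; beyond the scatter). Vinyl in place of (vinylcarbonyl)oxy shows a step of the same printed size, an at least 2900-fold higher number from compound 1 to compound 3 (3.46 log units; beyond the scatter), so the two different groups that leave are both tied to the same large change in this small set. The value of compound 3 is a limit of the assay, not a number, and this places it at the opposite end of the read-out: the limit of > 50 h in this assay, at which 1 of the 3 values shown sits.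

The compounds shown leave open how long compound 3 actually lasts, and which part of the larger groups goes with the short half-life, whether the carbonyl, the nitrogen or the double bonds. An ethyl group, a simple amide or an amine on this same aromatic carbon would begin to separate these parts, and would show whether the double bond of vinyl plays any part in the result.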